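This account rests on a few compounds, and the source may have more. Where it says the series, first, only, none or still open, it means among the compounds named here.

Among the measured compounds shown here, the two compounds measured so far share the core of compound 1 `Cc1ccc(S(=O)(=O)Nc2ccc3oc(-c4ccccc4)nc3c2)cc1` and differ only in the aryl group on the sulfonyl sulfur. In an assay on cells for inhibition of HSP60/HSP10 (Homo sapiens), with a stated time of 60 min (on this read-out higher numbers stand for weaker inhibition and lower numbers for stronger inhibition), compound 1 gives > 100000 nM, which is a limit of the assay rather than a number. Compound 2 `Cc1ccccc1S(=O)(=O)Nc1ccc2oc(-c3ccccc3)nc2c1` likewise returns only a limit in this assay, > 100000 nM. For the measured compounds named here, the single step that can be formed, a step that the two limits leave unreadable from compound 1 to compound 2, is unreadable in size and direction because both values sit at the limit of > 100000 nM in this assay, at which 2 of the 2 values shown sit. Compound 3 `C=Cc1ccc(S(=O)(=O)Nc2ccc3oc(-c4ccccc4)nc3c2)cc1` is not yet measured; it differs from compound 2 by 4-vinylphenyl in place of 2-methylphenyl on a sulfonyl sulfur. Going by the values given here, no measured step bears readably on this change, and the two limits give no basis for expecting a step beyond the scatter in either direction. Compound 3 is therefore expected to stand near the limit as well, at about 100000 nM in this assay, within 30000 nM to 300000 nM. The implied step a number no higher from compound 2 to compound 3 (the limit leaves the size open) is expected to be essentially none.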

Compound 3, half-maximal inhibitory concentration: > 100000 nM
Compound 3 was reported as a limit (the forecaster's own chance of this, stated with the estimate: 80%); the middle value sits exactly at the limit.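

Among the compounds shown here, no step among compound 1, compound 2 and compound 3 can be read in this assay, because all three values are limits of the assay rather than numbers: the limit of > 100000 nM in this assay, at which 3 of the 3 values shown sit.

The compounds shown leave open whether any aryl group on the sulfonyl sulfur of the shared core gives a readable value.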